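Biaryl sulfonamides and a trifluoromethylphenyl analogue

A few compounds are considered here, and "the series" means these few. Any claim that something is new, unique, unknown or untested is made for them only; others in the source may bear on it.

Measured so far:
- Compound 1, `CC1CCN(C2CCN(S(=O)(=O)c3cccc(-c4ccc5ccccc5c4)c3)CC2)CC1`: 2 nM
- Compound 2, `CC1CCN(C2CCN(S(=O)(=O)c3cccc(Cl)c3)CC2)CC1`: > 5000 nM
- Compound 3, `COc1cccc(S(=O)(=O)N2CCC(N3CCC(C)CC3)CC2)c1`: > 5000 nM

In a functional assay on DLD-1 cells (Homo sapiens) for antiproliferative activity, read by CellTiter-Glo, with a stated time of 72 h (on this read-out lower numbers stand for stronger inhibition and higher numbers for weaker inhibition), compound 1 gives 2 nM. For compound 2 the read-out in this assay is only a limit, > 5000 nM. For compound 3 the read-out is likewise only a limit, > 5000 nM, so compound 3 stands at the limit of > 5000 nM in this assay, at which 2 of the 3 values shown sit, together with compound 2, and a step that the two limits leave unreadable from compound 2 to compound 3.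

Compound 4, `CC1CCN(C2CCN(S(=O)(=O)c3cccc(-c4ccccc4C(F)(F)F)c3)CC2)CC1`, differs from compound 3 by 2-(trifluoromethyl)phenyl in place of methoxy on an aromatic carbon. Going by the values given here, the steps that bear on this are an at least 2500-fold higher number from compound 1 to compound 2 (3.39 log units; beyond the scatter) and an at least 2500-fold higher number from compound 1 to compound 3 (3.39 log units; beyond the scatter), both showing that a small substituent in place of an aromatic ring loses almost all activity. Restoring an aromatic ring is therefore expected to recover much of it: a large step downward, an at least 250-fold lower number from compound 3 to compound 4 (2.39 log units; beyond the scatter), is expected. Compound 4 is estimated at 20 nM, within 2 nM to 300 nM.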

Compound 4, half-maximal inhibitory concentration: 10 nM
The estimate for compound 4 lay 2.0-fold (0.30 log units) above the measured number, within the range that was stated.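

In this assay, a single substituted phenyl ring at this position also gives strong inhibition, so the two fused rings of naphthalen-2-yl are not required, with an at least 500-fold lower number from compound 3 to compound 4 (2.69 log units; beyond the scatter) and an at least 500-fold lower number from compound 2 to compound 4 (2.69 log units; beyond the scatter). Both steps start from a limit, so they give only a minimum size, and compound 2 and compound 3 remain at that limit: the limit of > 5000 nM in this assay, at which 2 of the 4 values shown sit. The exchange is still not neutral, with a 5.0-fold higher number from compound 1 to compound 4 (0.70 log units; beyond the scatter). The compounds shown leave open whether plain phenyl would serve as well, and whether an amine or a carboxylic acid on that ring would be tolerated.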